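The source may report more compounds than this note shows. Statements on the series, on what has been measured and on what is new or still open speak of the compounds shown alone.

Compound 1 `COc1cc(OC)cc(-c2cc3ccccc3[nH]2)c1` in an assay on isolated protein for inhibition of Aromatase (Homo sapiens), read by fluorescence, using NADPH, with a stated time of 30 min, tested at 50 uM (a lower number here means less inhibition, a higher number more inhibition at the concentration tested (going by the name of the read-out)), gives 9.18%.
Compound 2 `Nc1ccccc1C#Cc1cc(F)cc(F)c1` in this assay gives 9.27%.
Compound 3 `Nc1cccc(-c2cc3ccccc3[nH]2)c1` in this assay gives 26.7%.

Compound 3 stands highest of the three numbers, and both other compounds lie beyond the scatter below it. The next compound, compound 4 `COc1cccc(-c2cc3ccccc3[nH]2)c1`, has not been measured. It differs from compound 3 in one place: methoxy in place of amino on an aromatic carbon. Going by the values given here, no step between two measured compounds covers this exact change, so its size is open. Compound 1, which carries two methoxy groups on its six-membered ring, sits far below compound 3; on that basis compound 4 is expected to fall in this assay, by a step of about a number 14.7 percentage points lower from compound 3 to compound 4 (beyond the scatter) from its parent. Compound 4 is therefore estimated at 12%, with a range from 3% to 25%.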

Compound 4, a percentage reported as inhibition, at one concentration (the size of the read-out at that concentration, not a potency): 48.4%
Compound 4: middle estimate off by 36.4 percentage points, on the low side, and the stated range ends below it.
By their numbers in this assay, from the lowest: compounds 1 and 2 (each within the scatter of the next); then compound 3; then compound 4.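

The step of a number 21.7 percentage points higher from compound 3 to compound 4 (beyond the scatter) shows that methoxy on this aromatic carbon gives more inhibition than amino, so a methoxy here does not itself hold the number down. Going by these compounds alone, the step of a number 39.2 percentage points higher from compound 1 to compound 4 (beyond the scatter), with hydrogen in place of the second methoxy, ties the low number of compound 1 to that added methoxy and not to the one compound 4 keeps. Nothing measured here explains either step.

On these data alone, whether ethoxy or hydroxyl at this place would match methoxy remains open. So does whether a single methoxy on another carbon of the ring would give the same number.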